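Extending the Linker and Swapping the Amide Partner

The compounds below may be only part of what the source reports. "The series", "measured", "known", "first", "only" and "open" are said of these compounds alone.

Measured compounds:
- compound 1, `CCCCc1oc2ccccc2c1C(=O)c1ccc(OCC(=O)N2CCOCC2)cc1`: 45400 nM
- compound 2, `CCCCc1oc2ccccc2c1C(=O)c1ccc(OCC(=O)NCc2ccccc2)cc1`: 16300 nM
- compound 3, `CCCCc1oc2ccccc2c1C(=O)c1ccc(OCCCC(=O)N2CCOCC2)cc1`: 21400 nM

All three were tested in a functional assay on U-937 cells (Homo sapiens) for antiproliferative activity, read by MTT assay, with a stated time of 24 h; a lower number here means a stronger inhibitor, a higher number a weaker inhibitor. Compound 1 and compound 2 differ only in the group on the amide carbonyl, (benzylamino in place of morpholin-4-yl on a carbonyl carbon), and this change gave a 2.8-fold lower number from compound 1 to compound 2 (0.44 log units; beyond the scatter). Compound 3 shares the amide partner of compound 1 but has a longer chain between the ether oxygen and the carbonyl, (2-((morpholin-4-yl)carbonyl)ethyl in place of (morpholin-4-yl)carbonyl on a saturated chain carbon bound to an oxygen on an aromatic ring), which gave a 2.1-fold lower number from compound 1 to compound 3 (0.33 log units; beyond the scatter). Between compound 2 and compound 3 the numbers show a 1.3-fold higher number from compound 2 to compound 3 (0.12 log units; within the scatter).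

The unmeasured compound 4, `CCCCc1oc2ccccc2c1C(=O)c1ccc(OCCCC(=O)NCc2ccccc2)cc1`, carries the longer chain of compound 3 together with the amide partner of compound 2. Its difference from compound 3 is benzylamino in place of morpholin-4-yl on a carbonyl carbon, the same change as from compound 1 to compound 2, made at the same kind of position. For the measured compounds named here, because that earlier change produced a 2.8-fold lower number from compound 1 to compound 2 (0.44 log units; beyond the scatter), a step of roughly comparable size is expected here, a 2.7-fold lower number from compound 3 to compound 4 (0.43 log units; beyond the scatter), with the caveat that only one such pair is available. Compound 4 is therefore estimated at 8000 nM, expected to lie between 3500 nM and 18000 nM.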

Compound 4, half-maximal inhibitory concentration: 15800 nM
Compound 4: middle estimate off by 2.0-fold (0.30 log units), on the low side; the measured number falls inside the stated range.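

In this assay, for the compounds shown here, putting benzylamino in place of morpholin-4-yl on a carbonyl carbon, on the core with the longer chain, gives a 1.4-fold lower number from compound 3 to compound 4 (0.13 log units; within the scatter), so on this core the change produces no step that can be told apart from repeat-measurement noise. This does not prove that the change does nothing there, and it does not prove that the core alters its effect, since a single pair on each core is too little to settle either point. The two steps can be read as one effect of modest size or less, but no firm size for it can be given, and the comparison shows no difference between the cores: the same change on two cores in this assay, a 2.8-fold lower number (0.44 log units; beyond the scatter) from compound 1 to compound 2 and a 1.4-fold lower number (0.13 log units; within the scatter) from compound 3 to compound 4, 2.1-fold (0.31 log units) apart, within the scatter of two such steps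

Still open, as far as these compounds go, is whether the same swap behaves alike on a chain longer than that of compound 3. From the compounds shown here alone, it is also open whether another partner on the carbonyl, such as piperidin-1-yl or a simple dimethylamino group, or a free carboxylic acid in place of the amide, would give a step beyond the scatter.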